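The compounds below may be only part of what the source reports. "The series", "measured", "known", "first", "only" and "open" are said of these compounds alone.

Two measured compounds set the scene. Compound 1, with the structure `COc1ccc(/C=C/C(=O)c2cccc(-c3ccc(F)cc3)c2)cc1`, was tested in a functional assay on CNE-2 cells (Homo sapiens) for cytotoxicity, read by sulforhodamine B assay, with a stated time of 48 h (on this read-out lower numbers stand for stronger inhibition and higher numbers for weaker inhibition), and gives 5550 nM. Compound 2, with the structure `COc1cc(/C=C/C(=O)c2ccc(N)c(-c3ccc(F)cc3)c2)cc(Br)c1O`, gives 25500 nM in this assay. Of these two numbers, compound 1 holds the lower one, and the gap to compound 2 lies beyond the usual scatter of repeated measurements, so compound 1 is the stronger of the pair. Compound 2 differs from compound 1 in several places at once, so no single change can be read from that comparison.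

The next compound narrows the question to one change. Compound 3, with the structure `COc1ccc(/C=C/C(=O)c2ccc(N)c(-c3ccc(F)cc3)c2)cc1`, differs from compound 1 only in this way: amino in place of hydrogen on an aromatic carbon.

Among the compounds with values here, no measured pair shows what this change alone does. Because compound 2, which also carries an amino group among its other differences, gives 25500 nM, a slight drift toward weaker inhibition seems the more likely direction, though a step inside the scatter would not surprise. The estimated step from compound 1 to compound 3 in this assay is a 1.4-fold higher number from compound 1 to compound 3 (0.16 log units; within the scatter). For compound 3 the expected value in this assay is 8000 nM, with a range from 3000 nM to 20000 nM.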

Compound 3, half-maximal inhibitory concentration: 1600 nM
Estimate against measurement, compound 3: 5.0-fold (0.70 log units) above; the whole stated range lies above it.
By their numbers in this assay, from the lowest: compound 3; then compound 1; then compound 2.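

In this assay, placing an amino group on this aromatic carbon, ortho to a 4-fluorophenyl group and para to a large group, gives a 3.5-fold lower number from compound 1 to compound 3 (0.54 log units; beyond the scatter) and so moves the read-out toward stronger inhibition by more than the usual scatter of repeated measurements. Compound 1 and compound 2 differ in several places at once, so that earlier pair could not isolate the amino group, whereas this pair shows the effect of that one change on the core of compound 1. No available evidence explains how the amino group produces this step.

Going by these compounds, it remains open whether the gain is specific to the amino group or would also appear with another group at the same position, such as methylamino, dimethylamino or acetamido. Also unresolved is whether the amino group would give a similar step alongside the bromine and hydroxy groups of compound 2, as the matching compound without the amino group is not among those shown here.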